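A few compounds are considered here, and "the series" means these few. Any claim that something is new, unique, unknown or untested is made for them only; others in the source may bear on it.

Two amides built on one shared core have so far been tested in a functional assay (QGY7701 cells, Homo sapiens) for inhibition, read by MTT assay, with a stated time of 48 h; on this read-out lower numbers stand for stronger inhibition and higher numbers for weaker inhibition. There, compound 1 (`COc1cccc(NC(=O)/C=C/c2coc3cc(OC)ccc3c2=O)c1`) gives 39100 nM and compound 2 (`COc1ccc(CNC(=O)/C=C/c2coc3cc(OC)ccc3c2=O)cc1`) gives 15700 nM, the lowest of the two numbers. The next compound, compound 3 (`COc1ccc2c(=O)c(/C=C/C(=O)NCc3ccc(C)cc3)coc2c1`), differs from compound 2 only in the 4-methylbenzyl that replaces 4-methoxybenzyl, with methyl in place of methoxy on an aromatic carbon, para to a large group: methyl in place of methoxy on an aromatic carbon.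

Among the compounds with values here, only one measured step bears on this change, and only loosely: a 2.5-fold lower number from compound 1 to compound 2 (0.40 log units; beyond the scatter). That modest step came from putting 4-methoxybenzyl in place of 3-methoxyphenyl on an amide-type nitrogen. Within the data shown here, a methoxy is present on both sides of it, so no measurement yet shows what replacing the methoxy itself does. With so little to go on, no step beyond the scatter is expected in this assay, in either direction. The estimated step is a 1.0-fold higher number from compound 2 to compound 3 (0.01 log units; within the scatter). The estimate for compound 3 is 16000 nM, with an expected range from 7000 nM to 36000 nM.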

Compound 3, half-maximal inhibitory concentration: 10200 nM
The estimate for compound 3 lay 1.6-fold (0.20 log units) above the measured number; measured number inside the range.
By their numbers in this assay, from the lowest: compounds 3 and 2 (each within the scatter of the next); then compound 1.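

In this assay, within the data shown here, the exchange of 4-methoxybenzyl for 4-methylbenzyl gives the first direct reading of the methoxy itself: a 1.5-fold lower number from compound 2 to compound 3 (0.19 log units; within the scatter). At this place on the aromatic ring, then, methyl can stand in for methoxy, and the hydrogen-bond acceptor that leaves with the methoxy brings no step beyond the scatter in this read-out. The wider comparison gives a 3.8-fold lower number from compound 1 to compound 3 (0.58 log units; beyond the scatter), so both benzyl amides, compound 2 and compound 3, now stand below compound 1 by more than the scatter, and no listed compound goes against that, while nothing available gives a reason for these numbers.

The two groups tried at this place leave the reach of the position unknown, since a chlorine, a carboxylic acid or a dimethylamino group there could move the number in either direction or not at all. Also open, on these data alone, is whether a longer chain between the amide nitrogen and the aromatic ring would extend the gap from compound 1 or close it.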